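This account rests on a few compounds, and the source may have more. Where it says the series, first, only, none or still open, it means among the compounds named here.

Working notes on the series.

Two cores are in play. Compound 1 `C[C@@H]1CN(c2ccc(Cl)cc2)CCN1C(=O)C(=O)Nc1ccc2[nH]c(=O)oc2c1` and compound 3 `C[C@@H]1CN(c2ccc(F)c(F)c2)CCN1C(=O)C(=O)Nc1ccc2[nH]c(=O)oc2c1` share one core; compound 2 `C[C@@H]1CN(C(=O)C(=O)Nc2ccc3[nH]c(=O)oc3c2)CCN1c1ccc(Cl)cc1` has the same atoms as compound 1 joined differently, and the difference between the two cores is not broken down here. Compound 4 `C[C@@H]1CN(C(=O)C(=O)Nc2ccc3[nH]c(=O)oc3c2)CCN1c1ccc(F)c(F)c1` is not yet measured and stands to compound 2 as compound 3 stands to compound 1.

In an ADME assay on the whole organism (Rattus norvegicus, strain Sprague-Dawley) for pharmacokinetics, using cassette dosing, at a dose of 0.5 mg/kg by the intravenous route (a lower number here means slower removal, a higher number faster removal of the compound), compound 1 gives 5.4 mL/min/kg, and compound 3 gives 5.6 mL/min/kg. The change between them is 3,4-difluorophenyl in place of 4-chlorophenyl on an amine nitrogen in a ring, and it made a step of a 1.0-fold higher number from compound 1 to compound 3 (0.02 log units; within the scatter). Compound 2 gives 15.6 mL/min/kg in this assay, the highest of the three numbers, with its gap to each of the other two beyond the scatter.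

The change from compound 2 to compound 4 is 3,4-difluorophenyl in place of 4-chlorophenyl on an amine nitrogen in a ring. It is the same kind of change as that from compound 1 to compound 3, not the same: in compound 4 the amine nitrogen that carries the new group is next to the ring atom that bears a methyl group, whereas in compound 3 it lies two ring bonds from that atom. Among the compounds with values here, only one earlier step of this kind exists, so the expectation rests on it alone. Because the earlier step was a 1.0-fold higher number from compound 1 to compound 3 (0.02 log units; within the scatter), the step in this assay is expected at a 1.0-fold lower number from compound 2 to compound 4 (0.02 log units; within the scatter). Compound 4 is therefore estimated at 15 mL/min/kg in this assay, within an expected range from 8 mL/min/kg to 28 mL/min/kg.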

Compound 4, clearance: 15.9 mL/min/kg
Compound 4: middle estimate off by 1.1-fold (0.03 log units), on the low side, within the range that was stated.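

In this assay, 3,4-difluorophenyl in place of 4-chlorophenyl on the amine nitrogen in the ring gives a 1.0-fold higher number from compound 2 to compound 4 (0.01 log units; within the scatter), and the two steps of this kind agree across the two cores: the same change on two cores in this assay, a 1.0-fold higher number (0.02 log units; within the scatter) from compound 1 to compound 3 and a 1.0-fold higher number (0.01 log units; within the scatter) from compound 2 to compound 4, 1.0-fold (0.01 log units) apart, within the scatter of two such steps

Within this series, then, a step within the scatter on the core of compound 1 carried over to a step within the scatter on the core of compound 2, even though the amine nitrogen that carries the group in compound 4 is next to the ring atom that bears a methyl group. Within the data shown here, this rests on one pair of groups and two cores, and both steps are within the scatter, so it shows only that this one exchange gave no step beyond the scatter on either core, not that a change with a larger step would carry over in the same way. It also gives no account of what separates the two cores.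

Open, going by these compounds, is whether a nitrile, a methoxy group or an amine on the phenyl ring, in place of the halogens, would likewise give matching steps on both cores. Also open, on these data alone, is how an ethyl group in place of the methyl group would read on either core.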